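The compounds below may be only part of what the source reports. "The series", "measured", "known", "first", "only" and "open" are said of these compounds alone.

Working notes on the quinone amino-acid series.

Compound 3 `CC1=CCC[C@H]2[C@](C)(CC3=CC(=O)C=C(N[C@@H](C(=O)O)C(C)C)C3=O)[C@@H](C)CC[C@]12C` and compound 1 `CC1=CCC[C@H]2[C@](C)(CC3=CC(=O)C=C(NCC(=O)O)C3=O)[C@@H](C)CC[C@]12C` share the same core; compound 1 carries hydrogen in place of isopropyl on a saturated chain carbon bound to an amine nitrogen and a carbonyl carbon. In a functional assay on A549 cells (Homo sapiens) for cytotoxicity, read by MTT assay, with a stated time of 72 h (a lower number here means a stronger inhibitor, a higher number a weaker inhibitor), compound 3 gives 23800 nM, and compound 1 gives 46700 nM; the step is a 2.0-fold higher number from compound 3 to compound 1 (0.29 log units; within the scatter).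

Compound 2 `CC(C)C[C@H](NC1=CC(=O)C=C(C(C)(C)C)C1=O)C(=O)O` sits on a different core; the difference between the two cores is not broken down here. In this assay compound 2 gives 97900 nM, the highest number of the three measured compounds, beyond the scatter from both compound 1 and compound 3.

Compound 4 `C[C@H](NC1=CC(=O)C=C(C(C)(C)C)C1=O)C(=O)O` has not yet been measured. Relative to compound 2 it carries hydrogen in place of isopropyl on a saturated chain carbon, two bonds along the chain from an amine nitrogen and a carbonyl carbon. Among the compounds with values here, this is the same kind of change as the one from compound 3 to compound 1, though the place is not identical: in compound 1 the carbon is bound to an amine nitrogen and a carbonyl carbon, whereas in compound 4 it is two bonds along the chain from an amine nitrogen and a carbonyl carbon.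

Within the data shown here, the only precedent for removing the isopropyl is the step from compound 3 to compound 1, which stayed within the scatter, so for compound 4 the expected step in this assay is a 1.5-fold higher number from compound 2 to compound 4 (0.19 log units; within the scatter), resting on that single precedent and on the starting point of compound 2 at 97900 nM. With one precedent on a different core, the expectation is loose. On this basis compound 4 is estimated at 150000 nM, between 60000 nM and 400000 nM.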

Compound 4, half-maximal inhibitory concentration: > 200000 nM
Compound 4: no number, only a limit; the forecaster's own chance of this, stated with the estimate: 30%; middle value at least 1.3-fold (0.12 log units) away from the limit.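

In this assay compound 4 gives > 200000 nM, which is a limit of the assay and not a number. Read through that limit, the new step is an at least 2.0-fold higher number from compound 2 to compound 4 (0.31 log units; beyond the scatter), so on the core of compound 2 the number does not fall when hydrogen replaces the isopropyl, a change that also reads as isobutyl to methyl. The two cores show no reversal of direction, but they do not establish that the change carries over with the same size, and the place of the change is not identical on the two cores: the same change on two cores in this assay, a 2.0-fold higher number (0.29 log units; within the scatter) from compound 3 to compound 1 and an at least 2.0-fold higher number (0.31 log units; beyond the scatter) from compound 2 to compound 4; the limit leaves it open whether they differ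

The compounds shown leave open how far the true value of compound 4 lies past its limit, and so whether the step on the core of compound 2 is about the same size as the one on the core of compound 1 or larger. They also leave open how either core would respond to a different group on this chain, such as an amine, a carboxylic acid or a longer chain, so the two steps give a direction for this single change and no wider trend across the series.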